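The source may report more compounds than this note shows. Statements on the series, on what has been measured and on what is new or still open speak of the compounds shown alone.

In a functional assay on CCRF-CEM cells (Homo sapiens) for inhibition, read by cell counting, with a stated time of 96 h (on this read-out higher numbers stand for weaker inhibition and lower numbers for stronger inhibition), compound 1 `COc1ccc(N(C)c2nc(C)nc3c2nc(C)n3C)cc1` gives 6200 nM. Compound 2 `COc1ccc(Nc2nc(C)nc3c2nc(C)n3C)cc1` gives > 250000 nM, which is a limit of the assay and not a number. Compound 3 `CCN(c1ccc(OC)cc1)c1nc(C)nc2c1nc(C)n2C` has not yet been measured, and its structure departs from that of compound 2 in a single place: ethyl in place of hydrogen on a nitrogen on an aromatic ring. Among the compounds with values here, only one measured step bears on this change, and it concerns the same nitrogen. That step is an at least 40-fold higher number from compound 1 to compound 2 (1.60 log units; beyond the scatter), a large change beyond the scatter, with hydrogen in place of methyl. Read in reverse, it suggests that putting a carbon group back on this nitrogen could restore measurable inhibition in this assay. A large move towards a lower number is therefore expected, with compound 1 at 6200 nM as the nearest guide. Within the data shown here, no measured compound carries an ethyl group, so the estimate stays broad. The expected change is an at least 20-fold lower number from compound 2 to compound 3 (1.31 log units; beyond the scatter). For compound 3, the estimated value is 12000 nM, with an expected range of 3000 nM to 60000 nM.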

Compound 3, half-maximal inhibitory concentration: 16000 nM
Estimate against measurement, compound 3: 1.3-fold (0.12 log units) below; the range from low to high includes it.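

In this assay, ethyl on this nitrogen also gives a readable value, as methyl does in compound 1, so the return of inhibition is not tied to methyl alone: an at least 15-fold lower number from compound 2 to compound 3 (1.19 log units; beyond the scatter). The value of compound 2 is a limit of the assay and not a number, so this step gives only a minimum size, not an exact one: the limit of > 250000 nM in this assay, at which 1 of the 3 values shown sits. The choice of carbon group also matters, since extending methyl to ethyl is a modest change that still lies beyond the usual scatter, with weaker inhibition as the result: a 2.6-fold higher number from compound 1 to compound 3 (0.41 log units; beyond the scatter).

With only methyl and ethyl on this nitrogen, two points cannot show whether a longer chain such as propyl would weaken inhibition further, or whether a small ring such as cyclopropyl, or a chain ending in an amine or a carboxylic acid, would keep it. The compounds shown also do not explain why the nitrogen bearing hydrogen in compound 2 differs so sharply from those bearing a carbon group, and they cover only this one place on the shared core.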